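Trading Dimethylamino for Acetyl on Compound 1

The source may report more compounds than this note shows. Statements on the series, on what has been measured and on what is new or still open speak of the compounds shown alone.

Compound 1 `COc1cc(C)cc(-c2c(-c3ccnc(-c4ccc(N(C)C)cc4)c3)cnn2CC#N)c1` was measured in a functional assay on CAKI-1 cells (Homo sapiens) for cytotoxicity, read by sulforhodamine B assay, with a stated time of 48 h, tested at 100 nM (on this read-out lower numbers stand for a stronger effect and higher numbers for a weaker effect at the one concentration tested), where compound 1 gives -21%. That is the lowest of the three numbers seen so far. Compound 2 `COc1cc(C)cc(-c2nn(CC#N)cc2-c2ccc(-c3cccc(C(C)=O)c3)nc2)c1` gives 69% in this assay, and compound 3 `Cc1cc(O)cc(-c2nn(CC#N)cc2-c2ccnc(-c3ccc(N(C)C)cc3)c2)c1` gives 85%; both lie far above compound 1, beyond the scatter. Compound 4 `COc1cc(C)cc(-c2c(-c3ccnc(-c4ccc(C(C)=O)cc4)c3)cnn2CC#N)c1` has not yet been measured. It differs from compound 1 in one place: acetyl in place of dimethylamino on an aromatic carbon. Among the measured compounds shown here, no measured pair shows exactly this change. Compound 2, which also carries an acetyl group, gives 69% in this assay, a much weaker effect than compound 1. A sizeable rise toward a weaker effect is therefore expected, a number 66 percentage points higher from compound 1 to compound 4 (beyond the scatter). Compound 4 is estimated at 45%, within a range from 0% to 85%.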

Compound 4, a percentage reported as activity, at one concentration (the size of the read-out at that concentration, not a potency): 86%
Compound 4: the middle estimate sits 41 percentage points below what was measured; measured number above the stated range.
By their numbers in this assay, from the lowest: compound 1; then compound 2; then compounds 3 and 4 (each within the scatter of the next).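

Among the compounds shown here, replacing dimethylamino with acetyl on the aromatic carbon para to a large group gives a large loss of effect in this assay, a number 107 percentage points higher from compound 1 to compound 4 (beyond the scatter), the first reading of this change alone, as the earlier compounds differ from compound 1 in more than one place. The two groups match in heavy-atom and hydrogen-bond acceptor counts, so those counts do not separate them here. Nothing shown explains the step. Still open, going by these compounds, is how a primary amine or a carboxylic acid would read in this place.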